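Stability of the chain-linked amine series in mouse microsomes

The source may report more compounds than this note shows. Statements on the series, on what has been measured and on what is new or still open speak of the compounds shown alone.

Compound 3 `c1ccc2c(c1)CN[C@@H](CN(CCCN1CCNCC1)[C@H]1CCCc3cccnc31)C2` stands second highest of the three numbers in an ADME assay on microsomes from liver (Mus musculus) for metabolic stability, read by LC-MS, with a stated time of 10 min, tested at 0.5 uM (a higher number here means that more of the compound is left, a lower number that less of the compound is left), where compound 3 gives 92%. Compound 1 `c1ccc2c(c1)CN[C@@H](CN(CCCCN1CCNCC1)[C@H]1CCCc3cccnc31)C2` gives 96% in this assay, and compound 2 `c1ccc2c(c1)CN[C@@H](CN(CCN1CCNCC1)[C@H]1CCCc3cccnc31)C2` gives 79%. The steps between them are a number 17 percentage points lower from compound 1 to compound 2 (beyond the scatter), a number 4 percentage points lower from compound 1 to compound 3 (within the scatter) and a number 13 percentage points higher from compound 2 to compound 3 (beyond the scatter). Compound 4 `c1ccc2c(c1)CN[C@@H](CN(CC[C@@H]1CCCNC1)[C@H]1CCCc3cccnc31)C2` differs from compound 3 by piperidin-3-yl in place of (piperazin-1-yl)methyl on a saturated chain carbon, two bonds along the chain from an amine nitrogen. The step that bears most on this is a number 13 percentage points higher from compound 2 to compound 3 (beyond the scatter), a modest change at the same place, while a number 4 percentage points lower from compound 1 to compound 3 (within the scatter) stays within the scatter. A modest lowering is therefore expected, as a number 10 percentage points lower from compound 3 to compound 4 (within the scatter). Compound 4 is expected to give 82%, with a range from 66% to 95%.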

Compound 4, percent of the compound remaining: 23%
Compound 4: middle estimate off by 59 percentage points, on the high side; measured number outside the range, below it.
By their numbers in this assay, from the lowest: compound 4; then compound 2; then compounds 3 and 1 (each within the scatter of the next).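

Piperidin-3-yl in place of the piperazine-bearing groups, on a saturated chain carbon, two bonds along the chain from an amine nitrogen, weighs far more in this assay than any step among compounds 1 to 3: the readings are a number 69 percentage points lower from compound 3 to compound 4 (beyond the scatter) and a number 56 percentage points lower from compound 2 to compound 4 (beyond the scatter) and a number 73 percentage points lower from compound 1 to compound 4 (beyond the scatter) in turn. The stability of the piperazine compounds therefore does not carry over to this ring. Nothing at hand explains the drop.

Open, going by these compounds, is whether the loss follows the ring's hetero atom count, its attachment or its stereocentre. A piperidin-1-yl or morpholin-4-yl group at this place would help separate these.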